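Swapping a Halogen on the Aryl Ring of Compound 2

The source may report more compounds than this note shows. Statements on the series, on what has been measured and on what is new or still open speak of the compounds shown alone.

Compound 1 `O=C(C1CCCCC1)N1CC(c2nc(-c3cccc(F)c3)no2)C1` and compound 2 `O=C([C@H]1CC2CCC1C2)N1CC(c2nc(-c3cccc(F)c3)no2)C1` share a core and differ only in the group attached to the carbonyl carbon. In an assay on HEK293 cells for positive allosteric modulation of metabotropic glutamate receptor 5 (Homo sapiens), read by FLIPR (a higher number here means that more compound is needed for the effect, a lower number that less compound is needed), compound 1 gives 1000 nM, while compound 2 gives 72 nM. For the measured compounds named here, that single step, a 14-fold lower number from compound 1 to compound 2 (1.14 log units; beyond the scatter), is the only measured comparison available, and it leaves compound 2 with the lowest number of the two, with compound 1 as its sole neighbour.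

Compound 3 `O=C([C@H]1CC2CCC1C2)N1CC(c2nc(-c3cccc(Cl)c3)no2)C1` keeps the group on the carbonyl carbon of compound 2 and alters the aromatic ring instead: chloro in place of fluoro on an aromatic carbon. Going by the values given here, the one measured step concerns the group on the carbonyl carbon, not the aromatic ring, so nothing measured bears directly on this change. Among the compounds with values here, with no relevant step to draw on, the expectation is that the number stays close to that of compound 2, with no step beyond the scatter, so compound 3 is expected at 55 nM within 20 nM to 150 nM, which amounts to an estimated step of a 1.3-fold lower number from compound 2 to compound 3 (0.12 log units; within the scatter).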

Compound 3, half-maximal effective concentration: 74 nM
For compound 3 the middle estimate is 1.3-fold (0.13 log units) below the measured one, within the range that was stated.
By their numbers in this assay, from the lowest: compounds 2 and 3 (each within the scatter of the next); then compound 1.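

In this assay, going from 3-fluorophenyl to 3-chlorophenyl gives a 1.0-fold higher number from compound 2 to compound 3 (0.01 log units; within the scatter), so on this aromatic carbon the two halogens cannot be told apart by this read-out. For the compounds shown here, the only earlier step, a 14-fold lower number from compound 1 to compound 2 (1.14 log units; beyond the scatter), concerned the group on the carbonyl carbon and showed that the number can shift well beyond the scatter with a change at that end of the molecule, whereas this result shows a change at the aromatic end that leaves the number within the scatter, with the group on the carbonyl carbon of compound 2 held fixed. Nothing measured here offers an explanation for the match between fluoro and chloro at this position.

On these data alone, whether this indifference extends beyond these two halogens remains open: a bromo, a methyl, a methoxy or a nitrile on the same carbon could behave quite differently. As far as these compounds go, it is also open whether the same swap would read the same way with the six-membered ring of compound 1 on the carbonyl carbon, or with the chloro on another carbon of the aromatic ring.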